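The compounds below may be only part of what the source reports. "The series", "measured", "known", "first", "only" and "open" are said of these compounds alone.

Compound 1 `CC(C)N(Cc1cccc(OCCCCCC(=O)O)c1)C(=O)c1ccc(-c2cccc(O)c2)cc1` carries a free acid on the chain and a 3-hydroxyphenyl group. In an ADME assay on HEK293 cells (Homo sapiens) for cytotoxicity, read by CellTiter-Glo and resazurin assay, with a stated time of 72 h (on this read-out higher numbers stand for an effect only at larger amounts of compound and lower numbers for an effect already at smaller amounts), compound 1 is reported only as a limit, > 26000 nM. Compound 2 `CCOC(=O)CCCCCOc1cccc(CN(C(=O)c2ccc(-c3ccc4[nH]ccc4c3)cc2)C(C)C)c1` bears the ethyl ester instead. In this assay compound 2 also comes back as a limit, > 26000 nM. Compound 3 `CCOC(=O)CCCCCOc1cccc(CN(C(=O)c2ccc(-c3cc(OC)cc(OC)c3)cc2)C(C)C)c1` gives the same kind of result in this assay, a limit at > 26000 nM. The step that the two limits leave unreadable from compound 2 to compound 3 therefore cannot be read. Compound 3 stands at the limit of > 26000 nM in this assay, at which 3 of the 3 values shown sit, with nothing separating it from its neighbours. Compound 4 `CCOC(=O)CCCCCOc1cccc(CN(C(=O)c2ccc(-c3cccc(O)c3)cc2)C(C)C)c1` differs from compound 3 by 3-hydroxyphenyl in place of 3,5-dimethoxyphenyl on an aromatic carbon. Within the data shown here, no measured step gives a readable size for this change; the nearest comparison is compound 1, which carries the same 3-hydroxyphenyl group and sits at the limit > 26000 nM. The step that the limit leaves unreadable from compound 3 to compound 4 is therefore expected to be none beyond the scatter. Compound 4 is estimated at 40000 nM, in a range from 20000 nM to 150000 nM, most likely reported again only as a limit.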

Compound 4, half-maximal effective concentration: > 26000 nM
Compound 4: only a limit was reported (the forecaster's own chance of this, stated with the estimate: 85%); the middle value is on the limit's open side.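

In this assay compound 4 is again only a limit, > 26000 nM, so its steps from compound 1, compound 2 and compound 3 cannot be read. The compounds shown leave open whether the ester, acid or aryl changes alter cytotoxicity at all.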